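Taking One Methyl Off a Sulfonamide Nitrogen

The source may report more compounds than this note shows. Statements on the series, on what has been measured and on what is new or still open speak of the compounds shown alone.

Going by the values given here, only one number anchors this small series. In a physicochemical assay for lipophilicity, using the shake flask method (on this read-out lower numbers stand for lower lipophilicity and higher numbers for higher lipophilicity), compound 1 `CC(C)Oc1cc(Oc2ccc(S(C)(=O)=O)cc2)cc(-c2ncc(C#N)c(=O)[nH]2)c1` has the entry "not determined" (no result reported) and offers no comparison. Among the compounds with values here, compound 2 `Cc1cnc(-c2cc(Oc3ccc(S(=O)(=O)N(C)C)cc3)cc(O[C@@H](C)CO)c2)[nH]c1=O` gives 2.26 as the only measured value, so it cannot yet be ranked against anything. Compound 3 `CNS(=O)(=O)c1ccc(Oc2cc(O[C@@H](C)CO)cc(-c3ncc(C)c(=O)[nH]3)c2)cc1` awaits measurement and differs from compound 2 in one place: hydrogen in place of methyl on a sulfonamide nitrogen (hydrogen in place of methyl on a sulfonamide nitrogen, which turns dimethylsulfamoyl into methylsulfamoyl). Within the data shown here, no measured pair shows this change, so the expectation is a judgement from the structural change alone. A modest fall is expected in this assay with an estimated a number 0.36 log units lower from compound 2 to compound 3 (beyond the scatter) as its likely size. The estimate for compound 3 is 1.9 (expected range 1.5 to 2.3).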

Compound 3, distribution coefficient: 2.01
The estimate for compound 3 lay 0.11 log units below the measured number; the range from low to high includes it.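

In this assay, the series now has its first measured step at this sulfonamide nitrogen: a number 0.25 log units lower from compound 2 to compound 3 (within the scatter) for hydrogen in place of methyl. On this single pair, the change from dimethylsulfamoyl to methylsulfamoyl, which removes one carbon and adds no hydrogen-bond donor or acceptor by the count used here, cannot be told apart from the ordinary spread of repeated measurements. No supporting measurement is available to explain the result.

One pair cannot show whether this holds on other cores, and compound 1, with its methyl sulfone and no number in this assay, offers no comparison. Also open, from the compounds shown here alone, is how this assay would respond to a sulfonamide nitrogen carrying two hydrogens, a longer chain such as ethyl, or an amine-bearing chain.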